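Swapping 3-Hydroxyazetidin-1-yl for (Carbamoylmethyl)amino on an Amide

A few compounds are considered here, and "the series" means these few. Any claim that something is new, unique, unknown or untested is made for them only; others in the source may bear on it.

Of the compounds shown here, three sharing one core have been measured in a functional assay on cells for agonist activity at Glucose-dependent insulinotropic receptor (Homo sapiens), read by HTRF and cAMP accumulation, with a stated time of 30 min; on this read-out higher numbers stand for an effect only at larger amounts of compound and lower numbers for an effect already at smaller amounts. Compound 1 `CC(C)OC(=O)N1CCC2(CC1)CC(CCCOc1ccc(S(C)(=O)=O)c(F)c1)C2` carries a methylsulfonyl group and gives 18 nM. Compound 2 `CC(C)OC(=O)N1CCC2(CC1)CC(CCCOc1ccc(C(=O)NC3CC3)c(F)c1)C2`, with a cyclopropylcarbamoyl group in its place, gives 8 nM; the step reads a 2.3-fold lower number from compound 1 to compound 2 (0.35 log units; beyond the scatter). Compound 3 `CC(C)OC(=O)N1CCC2(CC1)CC(CCCOc1ccc(C(=O)N3CC(O)C3)c(F)c1)C2` bears a (3-hydroxyazetidin-1-yl)carbonyl group and gives 40 nM, the highest of the three numbers: a 2.2-fold higher number from compound 1 to compound 3 (0.35 log units; beyond the scatter) and a 5.0-fold higher number from compound 2 to compound 3 (0.70 log units; beyond the scatter).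

Compound 4 `CC(C)OC(=O)N1CCC2(CC1)CC(CCCOc1ccc(C(=O)NCC(N)=O)c(F)c1)C2` has not yet been measured. It differs from compound 3 in one place: (carbamoylmethyl)amino in place of 3-hydroxyazetidin-1-yl on a carbonyl carbon. Compound 3 and compound 4 are both amides on the carbonyl carbon attached to the aromatic carbon, so the step that bears most directly on this change is the one between the two measured amides, a 5.0-fold higher number from compound 2 to compound 3 (0.70 log units; beyond the scatter), where the amide with a hydrogen on its nitrogen gave the lower number. Compound 4 again has the amide hydrogen, now with a carbamoylmethyl chain rather than cyclopropyl. One would therefore expect the number to move back down, a 2.7-fold lower number from compound 3 to compound 4 (0.43 log units; beyond the scatter), although the chain in compound 4 is not the cyclopropyl of compound 2, so a full return to the level of compound 2 is not assured. The estimate for compound 4 in this assay is 15 nM, with a range from 5 nM to 50 nM.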

Compound 4, half-maximal effective concentration in the Glucose-dependent insulinotropic receptor assay: 48 nM
The estimate for compound 4 lay 3.2-fold (0.51 log units) below the measured number; the range from low to high includes it.
By their numbers in the Glucose-dependent insulinotropic receptor assay, from the lowest: compound 2; then compound 1; then compounds 3 and 4 (each within the scatter of the next).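

In the Glucose-dependent insulinotropic receptor assay the amide hydrogen on its own does not bring the number down: there is a 1.2-fold higher number from compound 3 to compound 4 (0.08 log units; within the scatter), so compound 4, at 48 nM with that hydrogen and no ring in the entering group, reads level with compound 3, at 40 nM, which has the hydrogen-free 3-hydroxyazetidin-1-yl amide. The low number of compound 2 therefore does not extend to every amide with that hydrogen, as the change of the group on the nitrogen gives a 6.0-fold higher number from compound 2 to compound 4 (0.78 log units; beyond the scatter), while the change from the sulfone gives a 2.7-fold higher number from compound 1 to compound 4 (0.43 log units; beyond the scatter), so compound 3 and compound 4 both stand above compound 1 and compound 2 alone goes against that pattern. The same exchange of groups gives a physicochemical assay for solubility, read by HPLC, in phosphate buffer, with a stated time of 24 h, at pH 6.8 (on this read-out lower numbers stand for lower solubility and higher numbers for higher solubility), a 1.1-fold lower number from compound 3 to compound 4 (0.03 log units; within the scatter), with compound 3 at 1.89 ug/mL and compound 4 at 1.77 ug/mL, and no measured evidence is available to account for any of these steps.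

The compounds shown leave open whether the lower number in compound 2 belongs to cyclopropyl in particular or would also be seen with a methyl, a cyclobutyl or a longer carbon chain on the amide nitrogen. They also leave open how a carboxylic acid or a primary amine at the end of the carbamoylmethyl chain would read.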